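Fluoro for Trifluoromethyl: Expected Solubility of Compound 3

A few compounds are considered here, and "the series" means these few. Any claim that something is new, unique, unknown or untested is made for them only; others in the source may bear on it.

Two related compounds have been measured in a physicochemical assay for solubility, in phosphate buffer, at pH 7.4; on this read-out higher numbers stand for higher solubility and lower numbers for lower solubility. Compound 1 `CCOC(=O)c1c(-c2ccccc2Cl)[nH]c2cc(OC)ccc2c1=O` gives 28000 nM in this assay. Compound 2 `CCOC(=O)c1c(-c2cccc(C(F)(F)F)c2)[nH]c2cccc(OC)c2c1=O` carries a trifluoromethyl group and has its methoxy group placed differently from compound 1. For compound 2 the result in this assay is only a limit of the method, > 100000 nM, and not a measured number. Going by the values given here, this is the limit of > 100000 nM in this assay, at which 1 of the 2 values shown sits, so compound 2 stands at the upper edge of what the measurement can report, and no step between compound 1 and compound 2 has been worked out; their two values simply show compound 1 with a number and compound 2 at the limit.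

Compound 3 `CCOC(=O)c1c(-c2cccc(F)c2)[nH]c2cccc(OC)c2c1=O` differs from compound 2 in one place: fluoro in place of trifluoromethyl on an aromatic carbon. Among the compounds with values here, no measured step involves such a change here, so the expectation rests on compound 2 alone. The step from compound 2 to compound 3 is expected to be small, none beyond the scatter or slightly toward higher solubility, a step that the limit leaves unreadable from compound 2 to compound 3. Compound 3 is therefore expected to give about 150000 nM, with a range from 60000 nM to 400000 nM, and most likely the method will again report only a limit.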

Compound 3, solubility: > 100000 nM
Compound 3: a limit, no number; the forecaster's own chance of this, stated with the estimate: 70%; the middle value is on the limit's open side.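

In this assay compound 2 and compound 3 both give a limit and not a number, so no step can be read for fluoro in place of trifluoromethyl: the limit of > 100000 nM in this assay, at which 2 of the 3 values shown sit. The two compounds leave open how far past the limit each one lies, and so whether this change shifts the read-out at all.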